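Methoxy ring exchange on the shared core

This account rests on a few compounds, and the source may have more. Where it says the series, first, only, none or still open, it means among the compounds named here.

Measured so far in an ADME assay on the whole organism (Rattus norvegicus) for metabolic stability, at a dose of 0.5 mg/kg by the intravenous route; a higher number here means that the compound lasts longer, a lower number that the compound disappears faster:
- compound 1 `COc1cc(OCc2cccc(-c3ccc(OC)nc3)c2)c2cc(-c3cn4nc(OC)sc4n3)oc2c1` gives 45 h
- compound 2 `COc1cc(OCc2cccc(-c3cnc(OC)cn3)c2)c2cc(-c3cn4nc(OC)sc4n3)oc2c1` gives 61 h

Going by the values given here, compound 2 stands within the scatter of the only other measured compound, as a 1.4-fold higher number from compound 1 to compound 2 (0.13 log units; within the scatter) shows. Compound 3 `COc1ccc(-c2cccc(COc3cc(OC)cc4oc(-c5cn6nc(OC)sc6n5)cc34)c2)nc1` differs from compound 2 by 5-methoxypyridin-2-yl in place of 5-methoxypyrazin-2-yl on an aromatic carbon on an aromatic carbon of a six-membered aromatic ring of carbon only, meta to a large group. Among the compounds with values here, the one measured step bearing on this, a 1.4-fold higher number from compound 1 to compound 2 (0.13 log units; within the scatter), also exchanges one methoxy-carrying six-membered aromatic ring for another. No step beyond the scatter is therefore expected in this assay, in either direction. Compound 3 is expected at 52 h within an estimated range from 28 h to 95 h as a working figure. The estimated 1.2-fold lower number from compound 2 to compound 3 (0.07 log units; within the scatter) stays within the scatter.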

Compound 3, half-life: 110 h
Compound 3: the middle estimate sits 2.1-fold (0.33 log units) below what was measured, and the stated range ends below it.
By their numbers in this assay, from the lowest: compounds 1, 2 and 3 (each within the scatter of the next, the first and the last beyond it).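

In this assay, going by these compounds alone, moving from 6-methoxypyridin-3-yl to 5-methoxypyridin-2-yl on the same aromatic carbon gives the first step beyond the scatter at this position (a 2.4-fold higher number from compound 1 to compound 3 (0.39 log units; beyond the scatter)), though a modest one. Exchanging 5-methoxypyrazin-2-yl for 5-methoxypyridin-2-yl stays within the scatter (a 1.8-fold higher number from compound 2 to compound 3 (0.26 log units; within the scatter)), so the pyrazine and this pyridine cannot be separated here. No measurement at hand gives a reason for either step.

As far as these compounds go, whether the methoxy group itself matters remains open, since all three rings carry one. An amine or a carboxylic acid in its place could test this.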